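The compounds below may be only part of what the source reports. "The series", "measured", "known", "first", "only" and "open" are said of these compounds alone.

Measured compounds:
- Compound 1, `CC(C)CCn1nc(-c2cccs2)c(O)c(C2=NS(=O)(=O)c3cc(N(C)S(C)(=O)=O)ccc3N2)c1=O`: in an in vitro ADME assay on microsomes from liver (Homo sapiens) for metabolic stability, tested at 5 uM (on this read-out lower numbers stand for a shorter-lived compound and higher numbers for a longer-lived compound), compound 1 gives 0.467 h.
- Compound 2, `CC(C)CCn1nc(-c2cccs2)c(O)c(C2=NS(=O)(=O)c3cc(CS(C)(=O)=O)ccc3N2)c1=O`: in this assay compound 2 gives 0.467 h.
- Compound 3, `CCC(C)(C)Cn1nc(-c2cccs2)c(O)c(C2=NS(=O)(=O)c3cc(NS(C)(=O)=O)ccc3N2)c1=O`: in this assay compound 3 gives > 1 h, which is a limit of the assay and not a number.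

Compound 3 therefore stands at the upper edge of what was measured: its half-life is given only as a limit, the point described by the limit of > 1 h in this assay, at which 1 of the 3 values shown sits, so how far it lies past the other two compounds is not known. The step now followed leads to compound 4, `CS(=O)(=O)Nc1ccc2c(c1)S(=O)(=O)N=C(c1c(O)c(-c3cccs3)nn(CC3CC3)c1=O)N2`, where the change is cyclopropyl in place of 1,1-dimethylpropyl on a saturated chain carbon bound to an aromatic nitrogen.

Going by the values given here, only one measured step exists, no change at the digits printed from compound 1 to compound 2 (within the scatter), and it alters a group on an aromatic carbon, not the chain on the aromatic nitrogen, so it does not speak to the present change. Among the compounds with values here, no measured pair compares chains on that nitrogen. The expectation for compound 4 can therefore rest only on compound 3 sitting at the limit: the step is estimated as a step that the limit leaves unreadable from compound 3 to compound 4. Compound 4 is expected to give about 1.5 h, with a range from 0.6 h to 4 h.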

Compound 4, half-life: > 1 h
Compound 4 gave a limit, no number; the forecaster's own chance of this, stated with the estimate: 60%; the middle value is on the limit's open side.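

In this assay compound 4 gives > 1 h as a limit of the assay and not a number. Going by these compounds alone, compound 3 also carries only a limit, so no step from it to compound 4 can be read: the limit of > 1 h in this assay, at which 2 of the 4 values shown sit. As far as these compounds go, how far past that limit the half-life of either compound lies stays open.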